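Solubility notes: carbonyl substituent changes on the shared core

The source may hold more compounds than are shown below. What is called first, only, known or untested is meant among the compounds shown, and "the series" means these compounds.

Three compounds of the series have numbers in a physicochemical assay for solubility, read by HPLC, in phosphate buffer, with a stated time of 4 h, at pH 7.4; a higher number here means a more soluble compound, a lower number a less soluble compound. Compound 1 `COCCOC(=O)c1cc(N)c(Nc2ccc(C#N)cc2)cc1Oc1c(C)cc(/C=C/C#N)cc1C` gives 0.77 ug/mL. Compound 2 `Cc1cc(/C=C/C#N)cc(C)c1Oc1cc(Nc2ccc(C#N)cc2)c(N)cc1C(=O)NCCCO` gives 1.01 ug/mL. Compound 3 `Cc1cc(/C=C/C#N)cc(C)c1Oc1cc(Nc2ccc(C#N)cc2)c(N)cc1C(=O)N1CC1` gives 1.2 ug/mL. Compound 2 stands second highest of the three, with a 1.2-fold higher number from compound 2 to compound 3 (0.07 log units; within the scatter) as the nearest neighbour and a 1.3-fold higher number from compound 1 to compound 2 (0.12 log units; within the scatter) as the furthest; both steps stay within the scatter, as does a 1.6-fold higher number from compound 1 to compound 3 (0.19 log units; within the scatter).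

The next compound is compound 4 `Cc1cc(/C=C/C#N)cc(C)c1Oc1cc(Nc2ccc(C#N)cc2)c(N)cc1C(=O)OCCC#N`, which differs from compound 2 by 2-cyanoethoxy in place of (3-hydroxypropyl)amino on a carbonyl carbon; cut one bond further out the change reads (3-hydroxypropyl)carbamoyl to (2-cyanoethoxy)carbonyl. The closest measured comparison is compound 1, which carries 2-methoxyethoxy on the same carbonyl carbon; the step from compound 1 to compound 2 was small and within the scatter, and so were the other two changes at this carbonyl carbon. Every change tried at this position has therefore left this assay about where it was.

For the step from compound 2 to compound 4 the expectation is a 1.2-fold lower number from compound 2 to compound 4 (0.07 log units; within the scatter), that is nothing beyond the scatter, leaning slightly downward toward the number of compound 1. Compound 4 is thus estimated at 0.85 ug/mL, with a range from 0.4 ug/mL to 1.8 ug/mL.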

Compound 4, solubility: 0.36 ug/mL
For compound 4 the middle estimate is 2.4-fold (0.37 log units) above the measured one; the measured number lies below the stated range.
By their numbers in this assay, from the lowest: compound 4; then compounds 1, 2 and 3 (each within the scatter of the next).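

Unlike the earlier changes on this carbonyl carbon, 2-cyanoethoxy carries this assay beyond the scatter, giving a 2.8-fold lower number from compound 2 to compound 4 (0.45 log units; beyond the scatter) in place of (3-hydroxypropyl)amino and a 3.3-fold lower number from compound 3 to compound 4 (0.52 log units; beyond the scatter) in place of aziridin-1-yl. An oxygen on the carbonyl carbon does not by itself go with the low number: compound 1 has one and stays within the scatter of compound 2 and compound 3, while with that oxygen kept, cyano in place of methoxy on the saturated chain carbon gives a 2.1-fold lower number from compound 1 to compound 4 (0.33 log units; beyond the scatter) on an otherwise unchanged group. Heavy-atom count does not separate the groups either, as (3-hydroxypropyl)amino and 2-cyanoethoxy both hold 5 heavy atoms.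

Nothing measured in this series gives a reason for the low number of compound 4. Open, from the compounds shown here alone, is whether (2-cyanoethyl)amino on the same carbonyl carbon would stay with compound 2 and compound 3 or fall with compound 4, and whether a chain carrying an amine or a carboxylic acid would move this assay beyond the scatter in the other direction.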